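A few compounds are considered here, and "the series" means these few. Any claim that something is new, unique, unknown or untested is made for them only; others in the source may bear on it.

Working notes on the series in an ADME assay on L132 cells (Homo sapiens) for cytotoxicity, read by MTT assay, with a stated time of 48 h; on this read-out higher numbers stand for weaker inhibition and lower numbers for stronger inhibition.

Compound 1 `C/C(=C\CC/C(C)=C/CC[C@@H]1[C@@]2(C)CCC(=O)C(C)(C)[C@H]2CC[C@@]1(C)O)CC/C=C(\C)C(=O)OCc1cn(-c2ccc(C(F)(F)F)cc2)nn1` sits at the limit of this assay: it gives > 150000 nM, a limit and not a number. Compound 2 `C/C(=C\CC/C(C)=C/CC[C@@H]1[C@@]2(C)CCC(=O)C(C)(C)[C@H]2CC[C@@]1(C)O)CC/C=C(\C)C(=O)OCc1cn(C[C@@H]2O[C@H](n3ccc(=O)[nH]c3=O)C[C@H]2O)nn1` gives 148000 nM in this assay. The two values show no gap worth reading, and the limit of > 150000 nM in this assay, at which 1 of the 2 values shown sits, marks where compound 1 stands.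

Compound 3 `COc1ccc(-n2cc(COC(=O)/C(C)=C/CC/C(C)=C/CC/C(C)=C/CC[C@@H]3[C@@]4(C)CCC(=O)C(C)(C)[C@H]4CC[C@@]3(C)O)nn2)cc1` differs from compound 1 by methoxy in place of trifluoromethyl on an aromatic carbon, that is, 4-(trifluoromethyl)phenyl to 4-methoxyphenyl. Among the measured compounds shown here, no measured step accompanies this change, so no shift beyond the scatter is expected: the estimated step from compound 1 is a step that the limit leaves unreadable from compound 1 to compound 3. Compound 3 is expected at 160000 nM, within 80000 nM to 320000 nM, most likely again as a limit.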

Compound 3, half-maximal inhibitory concentration: > 150000 nM
Compound 3: only a limit was reported (the forecaster's own chance of this, stated with the estimate: 70%); the middle value lies beyond the limit too.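

No step can be read from compound 1 to compound 3, as both values are limits and not numbers: the limit of > 150000 nM in this assay, at which 2 of the 3 values shown sit.

The compounds shown leave open whether 4-(trifluoromethyl)phenyl and 4-methoxyphenyl differ at all in this assay.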